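Hydroxy on the benzylamine arm of a pyroglutamine amidine series

The compounds below may be only part of what the source reports. "The series", "measured", "known", "first", "only" and "open" are said of these compounds alone.

Compound 1, `N=C(NCc1ccccc1)[C@@H]1CCC(=O)N1Cc1ccccc1[N+](=O)[O-]`, is the reference point of this set. In a functional assay on SH-SY5Y cells (Homo sapiens) for cytotoxicity, read by MTT assay, with stated times of 8 h, 30 min and 12 h, tested at 0.05 uM (a lower number here means a weaker effect, a higher number a stronger effect of the compound at the concentration tested), compound 1 gives 10.1%. Compound 2, `N=C(NCc1ccc(O)cc1)[C@@H]1CCC(=O)N1Cc1ccccc1[N+](=O)[O-]`, carries the change hydroxy in place of hydrogen on an aromatic carbon relative to compound 1, and in this assay compound 2 gives 20%. For the measured compounds named here, the step of a number 9.9 percentage points higher from compound 1 to compound 2 (within the scatter) is the only measured pair in which this change occurs so far, and it is small.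

Compound 3, `Cc1ccc(CN2C(=O)CC[C@H]2C(=N)NCc2ccccc2)cc1`, has a different core; the difference between the core of compound 3 and the core of compound 1 is not broken down here. In this assay compound 3 gives 17.1%, a number close to those of compound 1 and compound 2.

Compound 4, `Cc1ccc(CN2C(=O)CC[C@H]2C(=N)NCc2ccc(O)cc2)cc1`, is not yet measured. It differs from compound 3 by hydroxy in place of hydrogen on an aromatic carbon, the same change that separates compound 1 from compound 2: the place description is identical in both cases, an aromatic carbon of a six-membered aromatic ring of carbon only, para to a large group.

Because a number 9.9 percentage points higher from compound 1 to compound 2 (within the scatter) was within the scatter, the step from compound 3 to compound 4 is expected to be of similar size, estimated at a number 6.9 percentage points higher from compound 3 to compound 4 (within the scatter). Compound 4 is therefore expected to give about 24% in this assay, with a range from 12% to 36%.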

Compound 4, a percentage reported as activity, at one concentration (the size of the read-out at that concentration, not a potency): 20.5%
Compound 4: the middle estimate sits 3.5 percentage points above what was measured, within the range that was stated.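

Notes on carrying the change: hydroxy in place of hydrogen on an aromatic carbon has now been read on two cores in this assay, and the two steps cannot be told apart: the same change on two cores in this assay, a number 9.9 percentage points higher (within the scatter) from compound 1 to compound 2 and a number 3.4 percentage points higher (within the scatter) from compound 3 to compound 4, 6.5 percentage points apart, within the scatter of two such steps

On the core of compound 3 the step reads a number 3.4 percentage points higher from compound 3 to compound 4 (within the scatter), and the exchange of 2-nitrophenyl for 4-methylphenyl between the two hydroxy compounds reads a number 0.5 percentage points higher from compound 2 to compound 4 (within the scatter), so the change carries across these two cores without any measurable dependence on the core. This does not show that hydroxy itself alters the read-out, as each step stays within the scatter, and two pairs give no basis for a rule covering other cores in the series.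

The compounds shown leave open whether a methoxy group, an amine or a carboxylic acid in the same place on the benzyl arm would read any differently from hydroxy in this assay. Also open, going by these compounds, is how these compounds behave at any concentration other than the single one tested, as a read-out at one concentration gives the size of the effect there and not a potency.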